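A few compounds are considered here, and "the series" means these few. Any claim that something is new, unique, unknown or untested is made for them only; others in the source may bear on it.

Measured so far:
compound 1 `C[C@H](NC(=O)c1cc(C(F)(F)F)nn1C)c1nc(-c2ccnc(C3CC3)c2)no1`: 4.1
compound 2 `C[C@H](NC(=O)c1cc(C(F)(F)F)nn1C)c1nc(-c2ccnc(C(F)(F)F)c2)no1`: 3.6

Within the data shown here, both compounds have been measured in a physicochemical assay for lipophilicity (on this read-out higher numbers stand for higher lipophilicity and lower numbers for lower lipophilicity), and compound 1 stands highest of the two, at 4.1. Among the measured compounds shown here, the only measured step is a number 0.50 log units lower from compound 1 to compound 2 (beyond the scatter). This modest step, beyond the scatter, puts trifluoromethyl in place of cyclopropyl on an aromatic carbon.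

Compound 3 `COC(C)(C)c1cc(-c2noc([C@H](C)NC(=O)c3cc(C(F)(F)F)nn3C)n2)ccn1` has not yet been measured. It keeps the core of compound 1 and changes one group: 1-methoxy-1-methylethyl in place of cyclopropyl on an aromatic carbon. In words, 1-methoxy-1-methylethyl takes the place of cyclopropyl, next to the ring nitrogen.

For the measured compounds named here, the step to compound 2 also removes cyclopropyl, so it is the only measured guide, but it brings in a different group. Going by the values given here, no measured compound carries 1-methoxy-1-methylethyl, which leaves the size of the new step uncertain. Judging from a number 0.50 log units lower from compound 1 to compound 2 (beyond the scatter), a downward step of smaller size is expected in this assay, and it may not exceed the scatter. The estimated step is a number 0.20 log units lower from compound 1 to compound 3 (within the scatter). Compound 3 is therefore expected at 3.9, with an estimated range from 3.5 to 4.3.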

Compound 3, distribution coefficient: 3.8
The estimate for compound 3 lay 0.10 log units above the measured number; measured number inside the range.
By their numbers in this assay, from the lowest: compounds 2, 3 and 1 (each within the scatter of the next, the first and the last beyond it).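

Placing 1-methoxy-1-methylethyl on this aromatic carbon, next to the ring nitrogen, gives in this assay a number 0.30 log units lower from compound 1 to compound 3 (within the scatter) and also a number 0.20 log units higher from compound 2 to compound 3 (within the scatter). Compound 1 and compound 2 remain separated by a number 0.50 log units lower from compound 1 to compound 2 (beyond the scatter), yet compound 3 cannot be told apart from either of them, so the three groups do not form a clear order on this read-out. This position therefore accepts a group with more heavy atoms, no ring and one hydrogen-bond acceptor without a step beyond the usual scatter, although no measurement shown here explains this result.

The compounds shown cannot separate the contribution of the oxygen in 1-methoxy-1-methylethyl from that of its branched carbon framework, a question that tert-butyl, which keeps the branching but has no oxygen, could help to answer. They also leave open how this read-out would respond to an amine or a carboxylic acid at the same position.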